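The compounds below may be only part of what the source reports. "The series", "measured", "known", "first", "only" and "open" are said of these compounds alone.

Measured so far:
- compound 1 `O=c1cc(-c2ccccc2)oc2c(-c3cccc(F)c3)c(O)c(O)c(O)c12`: > 100000 nM
- compound 2 `O=c1cc(-c2ccc(N3CCN(c4ccc(O)cc4)CC3)cc2)oc2cc(O)c(O)c(O)c12`: > 100000 nM

In a toxicity assay on Huh-7 cells (Homo sapiens) for cytotoxicity, read by CCK-8 assay, with a stated time of 24 h (on this read-out higher numbers stand for lower toxicity in this test and lower numbers for higher toxicity in this test), compound 1 gives > 100000 nM, which is a limit of the assay and not a number. Compound 2 gives > 100000 nM, also a limit. Neither compound therefore has an exact value, and compound 1 stands at the limit of > 100000 nM in this assay, at which 2 of the 2 values shown sit.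

Compound 3 `O=c1cc(-c2ccccc2)oc2c(-c3ccccc3)c(O)c(O)c(O)c12` has not yet been measured in this assay. It keeps the core of compound 1, and the change is hydrogen in place of fluoro on an aromatic carbon, so 3-fluorophenyl becomes phenyl. Among the compounds with values here, no measured pair shows the size of such a change. The expectation is therefore no shift beyond the usual scatter, and a further limit is likely. The expected step of a number no higher from compound 1 to compound 3 (the limit leaves the size open) is an estimate only. The estimated value for compound 3 is 100000 nM, with an expected range from 40000 nM to 200000 nM.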

Compound 3, half-maximal cytotoxic concentration: 86300 nM
Estimate against measurement, compound 3: 1.2-fold (0.06 log units) above, and the stated range covers the measured number.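

In this assay compound 3 gives 86300 nM, the first exact number among the compounds shown, so the phenyl compound can be read on this scale. Hydrogen in place of fluoro on an aromatic carbon gives an at least 1.1-fold lower number from compound 1 to compound 3 (0.06 log units; that floor lies within the scatter), which means the change is known only as a floor, and that floor does not show that the fluoro group matters here. The other compounds still offer no exact number to compare with, as their values sit at one limit: the limit of > 100000 nM in this assay, at which 2 of the 3 values shown sit.

As far as these compounds go, the true size of the step from 3-fluorophenyl to phenyl stays open, as does whether another group at this place, such as chloro, methoxy, an amine or a carboxylic acid, would move the number further. This single pair also says nothing about the same change on a different core.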